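A few compounds are considered here, and "the series" means these few. Any claim that something is new, unique, unknown or untested is made for them only; others in the source may bear on it.

In a functional assay on K562 cells (Homo sapiens) for cytotoxicity, read by MTT assay, with a stated time of 72 h (on this read-out lower numbers stand for stronger inhibition and higher numbers for weaker inhibition), compound 1 `C=C1C(=O)[C@@]23C(=O)OC[C@]4(C(=O)CCC(C)(C)[C@H]4C=O)[C@@H]2CC[C@@H]1[C@H]3OC(C)=O` gives 1390 nM and compound 2 `C=C1C(=O)[C@@]23C(=O)OC[C@]4(C(=O)CCC(C)(C)[C@H]4C=O)[C@@H]2CC[C@@H]1[C@H]3OC(=O)CC` gives 1310 nM while compound 3 `C=C1C(=O)[C@@]23C(=O)OC[C@]4(C(=O)CCC(C)(C)[C@H]4C=O)[C@@H]2CC[C@@H]1[C@H]3OC(=O)c1ccc(F)cc1` gives 2700 nM on the same shared core. Compound 3 therefore sits level with compound 1 (a 1.9-fold higher number from compound 1 to compound 3 (0.29 log units; within the scatter)) and modestly apart from compound 2 (a 2.1-fold higher number from compound 2 to compound 3 (0.31 log units; beyond the scatter)).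

The next compound, compound 4 `C=C1C(=O)[C@@]23C(=O)OC[C@]4(C(=O)CCC(C)(C)[C@H]4C=O)[C@@H]2CC[C@@H]1[C@H]3OC(=O)c1ccc(Cl)cc1` differs from compound 3 in one place: chloro in place of fluoro on an aromatic carbon para to a large group. For the measured compounds named here, no measured step makes this exact swap, so the evidence is indirect. The closest comparisons are the two that brought in the 4-fluorophenyl group, one replacing methyl and the other replacing ethyl on a carbonyl carbon. Their sizes are given above, and neither goes past a modest step. Adding methyl in place of hydrogen on a saturated chain carbon bound to a carbonyl carbon gave even less (a 1.1-fold lower number from compound 1 to compound 2 (0.03 log units; within the scatter)). The new change exchanges only one halogen for another, so no step beyond the scatter is expected in this assay and neither direction is favoured. The estimated change is small (a 1.1-fold lower number from compound 3 to compound 4 (0.03 log units; within the scatter)). Compound 4 is expected at 2500 nM (estimated range 1200 nM to 5000 nM).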

Compound 4, half-maximal inhibitory concentration: 1380 nM
Compound 4: the middle estimate sits 1.8-fold (0.26 log units) above what was measured, and the stated range covers the measured number.
By their numbers in this assay, from the lowest: compounds 2, 4, 1 and 3 (each within the scatter of the next, the first and the last beyond it).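

For the compounds shown here, the first direct halogen exchange on this aromatic carbon, para to a large group, leaves the result within the scatter in this assay (a 2.0-fold lower number from compound 3 to compound 4 (0.29 log units; within the scatter)), so these two compounds cannot be told apart on this read-out. The 4-chlorophenyl group on the carbonyl carbon also matches the two small chains (a 1.0-fold lower number from compound 1 to compound 4 (0.00 log units; within the scatter); a 1.1-fold higher number from compound 2 to compound 4 (0.02 log units; within the scatter)), which shows that an aromatic ring at this position need not separate a compound from the short-chain compounds, even though the fluoro compound lay just beyond the scatter from compound 2 (a 2.1-fold higher number from compound 2 to compound 3 (0.31 log units; beyond the scatter)). Nothing available here explains these numbers or links them to any measured property of the halogens.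

The compounds shown leave open whether a group other than a halogen on the same aromatic carbon, such as an amine or a methoxy group, would move the number beyond the scatter. They also leave open how a plain phenyl or a longer chain on the carbonyl carbon would compare, and whether this flat picture holds in any cells other than those of this assay.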